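Half-Life Expected for a Benzyloxy Chain Analogue

The source may report more compounds than this note shows. Statements on the series, on what has been measured and on what is new or still open speak of the compounds shown alone.

In an ADME assay on microsomes from liver (Mus musculus) for metabolic stability, read by LC-MS, using NADPH, with stated times of 15 min and 60 min, tested at 4.6 uM (on this read-out higher numbers stand for a longer-lived compound and lower numbers for a shorter-lived compound), compound 1 (`CC(=O)N1CCC(c2ccc3c(c2)oc(=O)n3C(=O)NCCCCc2ccccc2)CC1`) gives 1 h and compound 2 (`CN1CCC(c2ccc3c(c2)oc(=O)n3C(=O)NCCCCc2ccc(F)cc2)CC1`) gives 0.5 h so that these two values stand within the usual scatter of each other. Compound 3 (`CN1CCC(c2ccc3c(c2)oc(=O)n3C(=O)NCCOCc2ccccc2)CC1`) departs from compound 2 in one place (benzyloxy in place of 2-(4-fluorophenyl)ethyl on a saturated chain carbon, two bonds along the chain from an amide-type nitrogen) with benzyloxy in place of 2-(4-fluorophenyl)ethyl on a saturated chain carbon, two bonds along the chain from an amide-type nitrogen. Among the compounds with values here, no measured pair of compounds differs in only one place, so the data offer no direct guide to this change. In this assay no step beyond the scatter is therefore expected, in either direction, and compound 2 at 0.5 h serves as the reference. The expected 1.3-fold lower number from compound 2 to compound 3 (0.10 log units; within the scatter) remains within the scatter. For compound 3 the estimated half-life is 0.4 h with an expected range of 0.15 h to 1 h in this measurement.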

Compound 3, half-life: 0.5 h
For compound 3 the middle estimate is 1.3-fold (0.10 log units) below the measured one; low and high end bracket the measured number.
By their numbers in this assay, from the lowest: compounds 2, 3 and 1 (each within the scatter of the next).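

In this assay the exchange of 2-(4-fluorophenyl)ethyl for benzyloxy on a saturated chain carbon, two bonds along the chain from an amide-type nitrogen, gives no change at the digits printed from compound 2 to compound 3 (within the scatter) and is the only comparison shown that differs in one place. It shows that, with the rest of the structure held constant, this replacement of the chain end leaves the half-life within the scatter, even though the oxygen enters and the fluorine leaves in the same step. No available evidence accounts for this result.

The compounds shown leave open how the oxygen and the fluorine would each read alone, since the step changes both together. They also leave open how a longer chain, an amine or a carboxylic acid at this position would read in this assay on the same core.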